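The compounds below may be only part of what the source reports. "The series", "measured", "known", "first", "only" and "open" are said of these compounds alone.

Compound 1 `CC1CN(C(=O)c2ccc(-c3ccc(NC(=O)Nc4ccc(Cl)c(C(F)(F)F)c4)cc3)cc2)CC(C)O1`: 2050 nM
Compound 2 `CC(NC(=O)c1ccc(-c2ccc(NC(=O)Nc3cc(C(F)(F)F)ccc3Cl)cc2)cc1)c1ccccc1`: 6570 nM

Measured in a functional assay on HT-29 cells (Homo sapiens) for inhibition, read by MTT assay, with a stated time of 120 h (a higher number here means a weaker inhibitor, a lower number a stronger inhibitor), compound 2 gives the higher of the two numbers, and compound 1 gives a lower one; that gap lies beyond the usual scatter. Compound 1 and compound 2 differ in more than one place, so the two values alone do not tell which change carries the gap. Compound 3 `CC1CN(C(=O)c2ccc(-c3ccc(NC(=O)Nc4cc(C(F)(F)F)ccc4Cl)cc3)cc2)CC(C)O1` arises from compound 2 by a single change: 2,6-dimethylmorpholin-4-yl in place of (1-phenylethyl)amino on a carbonyl carbon. This puts the group that compound 1 carries on the carbonyl carbon onto the rest of compound 2, so compound 3 shares one part with each measured compound. Among the compounds with values here, with no measured step for this exact change, the expectation rests on the two values shown. The estimate for compound 3 in this assay is 3500 nM, between 1200 nM and 10000 nM. The expected step of a 1.9-fold lower number from compound 2 to compound 3 (0.27 log units; within the scatter) leans toward a lower number, though it may well stay within the scatter.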

Compound 3, half-maximal inhibitory concentration: 1900 nM
The estimate for compound 3 lay 1.8-fold (0.27 log units) above the measured number; the range from low to high includes it.
By their numbers in this assay, from the lowest: compounds 3 and 1 (each within the scatter of the next); then compound 2.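

In this assay, 2,6-dimethylmorpholin-4-yl in place of (1-phenylethyl)amino on the carbonyl carbon gives a 3.5-fold lower number from compound 2 to compound 3 (0.54 log units; beyond the scatter) on an otherwise unchanged molecule, so the group at this position changes the reading. By contrast, 2-chloro-5-(trifluoromethyl)phenyl in place of 4-chloro-3-(trifluoromethyl)phenyl on the amide-type nitrogen gives a 1.1-fold lower number from compound 1 to compound 3 (0.03 log units; within the scatter), so the gap between compound 1 and compound 2 follows the group on the carbonyl carbon, not the one on the nitrogen. No measurement here explains why the two carbonyl groups read differently.

Still open, on these data alone, is whether the ring, its oxygen or its two methyl groups carry the step. A plain morpholin-4-yl or a piperazine ring on the same carbonyl carbon would help separate these parts.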